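Chalcone series with bis(dimethylaminomethyl)phenol core: cytotoxicity notes

This account rests on a few compounds, and the source may have more. Where it says the series, first, only, none or still open, it means among the compounds named here.

Measured so far:
- compound 1, `CN(C)Cc1cc(C(=O)/C=C/c2ccccc2)cc(CN(C)C)c1O`: 21900 nM
- compound 2, `CN(C)Cc1cc(C(=O)/C=C/c2c(Cl)cccc2Cl)cc(CN(C)C)c1O`: 5880 nM
- compound 3, `CN(C)Cc1cc(C(=O)/C=C/c2ccc(F)cc2)cc(CN(C)C)c1O`: 20000 nM

In a functional assay on cells (Tumor Cell line, Homo sapiens) for cytotoxicity (a lower number here means a stronger inhibitor, a higher number a weaker inhibitor), compound 3 gives 20000 nM, the second highest of the three numbers. Its nearest neighbour is compound 1 with 21900 nM; the two lie within the scatter of each other, as the step of a 1.1-fold lower number from compound 1 to compound 3 (0.04 log units; within the scatter) shows. Going by the values given here, the only step beyond the scatter in the set is a 3.7-fold lower number from compound 1 to compound 2 (0.57 log units; beyond the scatter), and in the reverse sense a 3.4-fold higher number from compound 2 to compound 3 (0.53 log units; beyond the scatter).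

The next compound, compound 4, `CN(C)Cc1cc(C(=O)/C=C/c2ccc(Br)cc2)cc(CN(C)C)c1O`, differs from compound 3 by one substituent: bromo in place of fluoro on an aromatic carbon.

Among the compounds with values here, no measured step bears directly on exchanging one halogen for another on this ring. Within the data shown here, the step of a 1.1-fold lower number from compound 1 to compound 3 (0.04 log units; within the scatter) shows that adding fluoro at this place left the number essentially where it was, and the only change that moved the number, a 3.7-fold lower number from compound 1 to compound 2 (0.57 log units; beyond the scatter), involved a different substitution pattern, so it cannot be transferred. On that basis no step beyond the scatter is expected; the estimated step of a 1.3-fold lower number from compound 3 to compound 4 (0.12 log units; within the scatter) is a slight lowering at most. For compound 4 the expected value in this assay is 15000 nM, with a range of 6000 nM to 40000 nM.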

Compound 4, half-maximal inhibitory concentration: 6310 nM
Estimate against measurement, compound 4: 2.4-fold (0.38 log units) above, and the stated range covers the measured number.
By their numbers in this assay, from the lowest: compounds 2 and 4 (each within the scatter of the next); then compounds 3 and 1 (each within the scatter of the next).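

At this place, on an aromatic carbon para to a large group, the halogen matters: in this assay the exchange of fluoro for bromo gives a 3.2-fold lower number from compound 3 to compound 4 (0.50 log units; beyond the scatter), so the silence of the site seen with fluoro does not extend to every substituent. Measured against the unsubstituted phenyl, bromo gives a 3.5-fold lower number from compound 1 to compound 4 (0.54 log units; beyond the scatter), the first single substituent at this place to give a step beyond the scatter, while a 1.1-fold higher number from compound 2 to compound 4 (0.03 log units; within the scatter) places the 4-bromophenyl and 2,6-dichlorophenyl compounds level with each other, so neither can be ranked above the other. No measurement available here accounts for the different outcomes with fluoro and bromo.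

Going by these compounds, whether chloro at this place behaves like fluoro or like bromo remains open, as does whether a non-halogen such as methyl or methoxy would also lower the number. Also open, on these data alone, is whether the step from 4-fluorophenyl to 4-bromophenyl would hold if a morpholine replaced the dimethylamino groups of the shared core.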